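A few compounds are considered here, and "the series" means these few. Any claim that something is new, unique, unknown or untested is made for them only; others in the source may bear on it.

Measured compounds in an ADME assay on Vero cells (Chlorocebus sabaeus) for cytotoxicity, read by MTT assay, with a stated time of 72 h; on this read-out lower numbers stand for higher toxicity in this test and higher numbers for lower toxicity in this test:
compound 1 `CCC(C)C(=O)N1CCN(c2nc(=O)c3cc(C(F)(F)F)cc([N+](=O)[O-])c3s2)CC1`, a limit of > 125000 nM.
compound 2 `O=C(c1cccc(F)c1)N1CCN(c2nc(=O)c3cc(C(F)(F)F)cc([N+](=O)[O-])c3s2)CC1`, a limit of > 125000 nM.

Both readings are limits, so the step that the two limits leave unreadable from compound 1 to compound 2 cannot be read; both sit at the limit of > 125000 nM in this assay, at which 2 of the 2 values shown sit. Compound 2 therefore stands only at a limit of this assay, with no number. Compound 3 `CCCC(=O)N1CCN(c2nc(=O)c3cc(C(F)(F)F)cc([N+](=O)[O-])c3s2)CC1` differs from compound 2 by propyl in place of 3-fluorophenyl on a carbonyl carbon. Within the data shown here, the one measured step bearing on this region is unreadable, so no size beyond the scatter is expected in this assay. Compound 3 is estimated at 150000 nM, with a range from 60000 nM to 400000 nM. This estimate means an expected step that the limit leaves unreadable from compound 2 to compound 3.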

Compound 3, half-maximal cytotoxic concentration: > 125000 nM
Compound 3: only a limit was reported (the forecaster's own chance of this, stated with the estimate: 80%); the middle value is on the limit's open side.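

No new step can be read among compound 1, compound 2 and compound 3 in this assay, as all three readings are limits and not numbers: the limit of > 125000 nM in this assay, at which 3 of the 3 values shown sit. The compounds shown leave open where the half-maximal cytotoxic concentration of any of them lies, and whether the group on the carbonyl carbon alters it.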